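Cytotoxicity in a methylenecyclopropane nucleoside pair, inverted configuration

The source may report more compounds than this note shows. Statements on the series, on what has been measured and on what is new or still open speak of the compounds shown alone.

Two compounds of the series carry a measured cytotoxicity value. Compound 1 `Nc1nc2c(ncn2/C=C2/C[C@H]2[C@@H](O)CO)c(=O)[nH]1` gives 78000 nM in an ADME assay on Akata cells (Homo sapiens) for cytotoxicity; on this read-out lower numbers stand for higher toxicity in this test and higher numbers for lower toxicity in this test. Compound 2 `Nc1ncnc2c1ncn2/C=C1\C[C@@H]1[C@@H](O)CO` gives 50600 nM in this assay; compound 1 and compound 2 sit together within the usual scatter of this test, so no order between them can be read from these two numbers.

Compound 3 `Nc1nc2c(ncn2/C=C2/C[C@@H]2[C@H](O)CO)c(=O)[nH]1` has not yet been measured in this assay. It differs from compound 1 in this way: the two compounds have the same atoms and bonds and differ only in configuration as drawn: 2 of 3 stereo elements differ; a stereocentre at a saturated ring carbon is drawn R in compound 1 and S in compound 3; a stereocentre at a saturated chain carbon is drawn R in compound 1 and S in compound 3.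

Among the compounds with values here, no comparison between measured compounds shows what such an inversion of configuration does to cytotoxicity here, so the step has to be guessed from the general behaviour of the pair, both of which show weak toxicity. The expectation is a step from compound 1 to compound 3 of a 1.2-fold higher number from compound 1 to compound 3 (0.06 log units; within the scatter), not beyond the scatter. Compound 3 is therefore estimated at 90000 nM in this assay, with a plausible range from 35000 nM to 250000 nM.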

Compound 3, half-maximal cytotoxic concentration: 54000 nM
Compound 3: the middle estimate sits 1.7-fold (0.22 log units) above what was measured; measured number inside the range.
By their numbers in this assay, from the lowest: compounds 2, 3 and 1 (each within the scatter of the next).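

Within the data shown here, the pair gives the first reading of an inversion of configuration, and the reading is a clean one because nothing else varies: the fact that compounds 1 and 3 differ only in the configuration as drawn. In this assay, inverting the saturated ring carbon and the saturated chain carbon together gives a 1.4-fold lower number from compound 1 to compound 3 (0.16 log units; within the scatter), so this test does not separate the two configurations. Inversion at these two stereocentres together therefore has no readable effect on this read-out in this pair.

From the compounds shown here alone, what each stereocentre does alone stays open, since both change together here and opposing effects cannot be ruled out. Also open, going by these compounds, is whether a carboxylic acid or a longer chain in place of the hydroxyl-bearing side chain would move the number beyond the scatter in this assay.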